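Replacing an Aryl Substituent with Methylsulfanyl on the Core

The source may report more compounds than this note shows. Statements on the series, on what has been measured and on what is new or still open speak of the compounds shown alone.

Measured so far:
Compound 1, `O=C(CCCCCCc1ccccc1)c1ncc(-c2cccc(O)c2)o1`: 50 nM
Compound 2, `O=C(CCCCCCc1ccccc1)c1ncc(-c2ccncn2)o1`: 2.3 nM

In an assay (Rattus norvegicus) for inhibition of Fatty-acid amide hydrolase 1 (Homo sapiens) (a lower number here means a stronger inhibitor, a higher number a weaker inhibitor), compound 2 gives the lowest of the two numbers; its nearest neighbour is compound 1, separated by a 22-fold lower number from compound 1 to compound 2 (1.34 log units; beyond the scatter), a large step beyond the scatter. Compound 3, `CSc1cnc(C(=O)CCCCCCc2ccccc2)o1`, has not yet been measured. It differs from compound 2 in one place: methylsulfanyl in place of pyrimidin-4-yl on an aromatic carbon. The change sits on an aromatic carbon of the five-membered ring, next to the ring oxygen.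

Going by the values given here, only one measured step bears on this: the exchange of one aromatic group for another on the same carbon, which moved the number by a 22-fold lower number from compound 1 to compound 2 (1.34 log units; beyond the scatter). Among the compounds with values here, no measured compound shows what happens when the aromatic group at that carbon is removed altogether and a small group takes its place, so the direction is less certain. Since the aromatic group at that position moved the number so strongly, the author expects compound 3 to lose potency, giving a higher number with a step of about a 43-fold higher number from compound 2 to compound 3 (1.64 log units; beyond the scatter). Compound 3 is therefore estimated at 100 nM, within a range of 20 nM to 600 nM.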

Compound 3, inhibition constant: 25 nM
The estimate for compound 3 lay 4.0-fold (0.60 log units) above the measured number; measured number inside the range.
By their numbers in this assay, from the lowest: compound 2; then compounds 3 and 1 (each within the scatter of the next).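

In this assay, the exchange at this aromatic carbon, next to the ring oxygen, shows that a ring is not required there to reach the level of compound 1: methylsulfanyl, with no ring and only 2 heavy atoms, stands level with 3-hydroxyphenyl (a 2.0-fold lower number from compound 1 to compound 3 (0.30 log units; within the scatter)). Pyrimidin-4-yl remains clearly apart from methylsulfanyl (an 11-fold higher number from compound 2 to compound 3 (1.04 log units; beyond the scatter)), so among these three compounds the low number belongs to compound 2 alone, and compound 1, though it also carries an aromatic ring at this carbon, does not share it. The data shown offer no measurement that would explain either step.

From the compounds shown here alone, it remains open whether the sulfur of compound 3 matters, which methoxy or ethyl at the same carbon could test, and whether a longer thioether chain or an amine there would stay level with methylsulfanyl or move away from it. Going by these compounds, it is equally open which feature sets pyrimidin-4-yl apart, a question that pyridin-2-yl, pyridin-4-yl or plain phenyl on the shared core could address.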